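Halogen Swap on the Aromatic Ring: Bromo to Chloro

This account rests on a few compounds, and the source may have more. Where it says the series, first, only, none or still open, it means among the compounds named here.

Measured compounds:
Compound 1 `COC(=O)[C@@]1(C)CC[C@@H]2C3=C1CC[C@@H](C)[C@]3(C)C[C@@H]1c3cccc(C)c3N[C@H]21` gives 31000 nM in a functional assay on SW1573 cells (Homo sapiens) for inhibition, read by sulforhodamine B assay, with a stated time of 48 h; on this read-out lower numbers stand for stronger inhibition of growth and higher numbers for weaker inhibition of growth.
Compound 2 `COC(=O)[C@@]1(C)CC[C@@H]2C3=C1CC[C@@H](C)[C@]3(C)C[C@@H]1c3cccc(Br)c3N[C@H]21` gives 44000 nM in this assay.

Within the data shown here, compound 2 stands at the higher of the two numbers measured so far, but its nearest neighbour is compound 1, and the step of a 1.4-fold higher number from compound 1 to compound 2 (0.15 log units; within the scatter) lies within the scatter, so the two cannot be told apart. Compound 3 `COC(=O)[C@@]1(C)CC[C@@H]2C3=C1CC[C@@H](C)[C@]3(C)C[C@@H]1c3cccc(Cl)c3N[C@H]21` differs from compound 2 only by chloro in place of bromo on an aromatic carbon. Among the measured compounds shown here, the only measured step that bears on this change is the exchange of methyl for bromo on the same aromatic carbon, which gave a 1.4-fold higher number from compound 1 to compound 2 (0.15 log units; within the scatter). Since that larger exchange produced no step beyond the scatter, the smaller exchange of bromo for chloro is expected to give no step beyond the scatter either, so a 1.2-fold lower number from compound 2 to compound 3 (0.06 log units; within the scatter) is expected. Compound 3 is therefore estimated at 38000 nM in this assay, with a range from 15000 nM to 95000 nM.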

Compound 3, concentration for 50% growth inhibition: 49000 nM
The estimate for compound 3 lay 1.3-fold (0.11 log units) below the measured number, within the range that was stated.
By their numbers in this assay, from the lowest: compounds 1, 2 and 3 (each within the scatter of the next).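

In this assay, the exchange of bromo for chloro gives a 1.1-fold higher number from compound 2 to compound 3 (0.05 log units; within the scatter), and the exchange of methyl for chloro gives a 1.6-fold higher number from compound 1 to compound 3 (0.20 log units; within the scatter). Even the widest of the three comparisons now available stays inside the scatter, so methyl, bromo and chloro on this aromatic carbon cannot be told apart by growth inhibition in these cells. No separate measurement is available to explain this result.

Still open, from the compounds shown here alone, is whether this aromatic carbon would respond to a different kind of group, such as an amine, a carboxylic acid or a longer chain. Going by these compounds, it is also open whether the same three groups would remain indistinguishable on another carbon of this six-membered aromatic ring.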